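Trading methoxy for cyano at the solubility limit

A few compounds are considered here, and "the series" means these few. Any claim that something is new, unique, unknown or untested is made for them only; others in the source may bear on it.

Of the compounds shown here, three built on one shared core have been measured in a physicochemical assay for solubility, using the shake flask method, measured as kinetic solubility, with a stated time of 20 h, at pH 2; on this read-out lower numbers stand for lower solubility and higher numbers for higher solubility. Compound 1 `COc1ccnc(Nc2cc3[nH]c(-c4cccc(C(F)(F)F)c4)nc3cn2)c1` gives only a limit of the assay, < 5000 nM. Compound 2 `COc1ccc(Nc2cc3[nH]c(-c4cccc(C(F)(F)F)c4)nc3cn2)nc1` likewise gives only a limit, < 5000 nM. Compound 3 `Fc1ccc(-c2nc3cnc(Nc4ccccn4)cc3[nH]2)cc1C(F)(F)F` gives a numbered value, 7000 nM. The step that the two limits leave unreadable from compound 1 to compound 2 cannot be sized because both of its ends rest at the limit (the limit of < 5000 nM in this assay, at which 2 of the 3 values shown sit). Compound 2 therefore stands at that limit, with one neighbour also at a limit and one carrying a number.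

Compound 4 `N#Cc1ccc(Nc2cc3[nH]c(-c4cccc(C(F)(F)F)c4)nc3cn2)nc1` differs from compound 2 by cyano in place of methoxy on an aromatic carbon. Among the compounds with values here, no measured step swaps a methoxy for a cyano, so the only guide is the set of values themselves, two of them at the limit and one a modest number. For compound 4 the expected step is a step that the limit leaves unreadable from compound 2 to compound 4, with a fair chance that this assay again reports only a limit rather than a number. Compound 4 is estimated at 3000 nM, within the range 700 nM to 10000 nM.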

Compound 4, solubility: < 5000 nM
Compound 4: no number, only a limit; the forecaster's own chance of this, stated with the estimate: 60%; the middle value lies beyond the limit too.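

Within the data shown here, no step to compound 4 can be read from compound 1 or compound 2, because all three compounds rest at a limit rather than a number: the limit of < 5000 nM in this assay, at which 3 of the 4 values shown sit. Left open is whether compound 1, compound 2 and compound 4 truly differ in this assay, and so what cyano in place of methoxy does there.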